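This account rests on a few compounds, and the source may have more. Where it says the series, first, only, none or still open, it means among the compounds named here.

Working notes on the series. The shared core appears in compound 1 `N[C@H]1CC[C@H](Nc2c(C(=O)NCc3ccco3)nc(Br)c3cccnc23)CC1`, compound 2 `Nc1ccc(Nc2c(C(=O)NCc3ccc(F)cc3)nc(Br)c3cccnc23)cc1` and compound 3 `N[C@H]1CC[C@H](Nc2c(C(=O)NCc3ccc(Cl)cc3Cl)nc(Br)c3cccnc23)CC1`. For the measured compounds named here, in a functional assay on MCF7 cells (Homo sapiens) for cytotoxicity, read by MTT assay, with a stated time of 72 h (a lower number here means a stronger inhibitor, a higher number a weaker inhibitor), compound 2 gives 4000 nM; this is the only number available. In this assay compound 1 gives "not determined" (no result reported) and compound 3 gives "not determined" (no result reported). Compound 4 `COC(=O)CNc1c(C(=O)NCc2ccc(F)cc2)nc(Br)c2cccnc12` is the next to be tested in this assay. It differs from compound 2 in one place: (methoxycarbonyl)methyl in place of 4-aminophenyl on a nitrogen on an aromatic ring. Going by the values given here, no pair of measured compounds differing in one place exists, so this step has no precedent. The expectation is a step toward weaker inhibition, of a 2.0-fold higher number from compound 2 to compound 4 (0.30 log units; within the scatter), somewhat beyond the scatter. Compound 4 is accordingly estimated at 8000 nM, with a range from 2000 nM to 30000 nM.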

Compound 4, half-maximal inhibitory concentration: > 10000 nM
Compound 4: only a limit was reported; the forecaster's own chance of this, stated with the estimate: 25%; middle value at least 1.2-fold (0.09 log units) from the limit.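

In this assay compound 4 gives > 10000 nM, which is a limit of the assay and not a number. For the compounds shown here, putting (methoxycarbonyl)methyl in place of 4-aminophenyl on a nitrogen on an aromatic ring gives an at least 2.5-fold higher number from compound 2 to compound 4 (0.39 log units; beyond the scatter), the first sign that the group at this position matters for the read-out. The true size of the step stays unknown: the limit of > 10000 nM in this assay, at which 1 of the 4 values shown sits.

On these data alone, whether the weaker result follows from losing the ring or from gaining the ester stays open. A plain phenyl, or a carboxylic acid in place of the ester, would help separate the two.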